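The source may report more compounds than this note shows. Statements on the series, on what has been measured and on what is new or still open speak of the compounds shown alone.

Measured in a functional assay on MV4-11 cells (Homo sapiens) for antiproliferative activity, read by resazurin assay, with a stated time of 72 h; a lower number here means a stronger inhibitor of growth, a higher number a weaker inhibitor of growth:
- compound 1 `CC(=O)N1CCN(c2ccc(Nc3nccc(-c4c[nH]c5cccnc45)n3)cc2)CC1`: 420 nM
- compound 2 `CC(=O)N1CCCN(c2cccc(Nc3nccc(-c4c[nH]c5ncccc45)n3)c2)CC1`: 20 nM
- compound 3 `CN1CCN(c2cccc(Nc3nccc(-c4cn(C)c5ncccc45)n3)c2)CC1`: 24 nM

Compound 1 stands highest of the three, the weakest inhibitor of growth here. Compound 2 and compound 3 lie within the scatter of each other.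

Next is compound 4 `CC(=O)N1CCN(c2ccc(Nc3nccc(-c4cn(C)c5ncccc45)n3)cc2)CC1`, which keeps the rest of compound 1 and changes one group on an aromatic carbon: a group of 10 heavy atoms (8 carbon, 2 nitrogen; one five-membered aromatic ring with 1 hetero atom, one six-membered aromatic ring with 1 hetero atom) in place of a group of 9 heavy atoms (7 carbon, 2 nitrogen; one five-membered aromatic ring with 1 hetero atom, one six-membered aromatic ring with 1 hetero atom), on an aromatic carbon. Within the data shown here, the entering group is the one carried by compound 3, at 24 nM. Among the measured compounds shown here, compound 3 also differs from compound 4 elsewhere, and no measured pair isolates this change, so only part of that gap is expected to carry over. A drop beyond the scatter is expected in this assay, a 3.8-fold lower number from compound 1 to compound 4 (0.58 log units; beyond the scatter). The estimated value for compound 4 is 110 nM, with an expected range of 35 nM to 350 nM.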

Compound 4, concentration for 50% growth inhibition: 74 nM
Beside the measured number, compound 4's estimate is 1.5-fold (0.17 log units) above it, within the range that was stated.
By their numbers in this assay, from the lowest: compounds 2 and 3 (each within the scatter of the next); then compound 4; then compound 1.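

Among these compounds, this is the first single-place reading at this aromatic carbon of the six-membered ring with 2 nitrogen: in this assay, the exchange gives a 5.7-fold lower number from compound 1 to compound 4 (0.75 log units; beyond the scatter). The position therefore responds to a change of this group while the rest of compound 1 stays fixed. Nothing on hand explains the size of this step.

The exchange replaces the whole group, so the contribution of the extra carbon cannot be separated from the rest of the change. Going by these compounds, whether an ethyl or cyclopropyl group on the entering ring system would go further remains open.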